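The source may hold more compounds than are shown below. What is called first, only, known or untested is meant among the compounds shown, and "the series" means these compounds.

Compound 1 `N#Cc1c(N)nc(SCc2cccc(C(N)=O)c2)c(C#N)c1-c1ccc(OCC2CC2)cc1` and compound 2 `CCOc1ccc(-c2c(C#N)c(N)nc(SCC(N)=O)c2C#N)cc1` share a core but differ at more than one place. In an assay on CHO cells for displacement of a labelled ligand from adenosine receptor A1 (Homo sapiens), read by scintillation counting, with a stated time of 90 min (on this read-out higher numbers stand for weaker inhibition and lower numbers for stronger inhibition), compound 1 gives 83 nM, the lower of the two numbers shown, while compound 2 gives 345 nM, a gap beyond the usual scatter. Compound 3 `N#Cc1c(N)nc(SCc2ncc[nH]2)c(C#N)c1-c1ccc(OCC2CC2)cc1` arises from compound 1 by a single change: 1H-imidazol-2-yl in place of 3-carbamoylphenyl on a saturated chain carbon bound to a sulfur. Within the data shown here, no measured pair shows this change, so its effect is open. The step is expected to be modest and toward weaker inhibition, a 2.4-fold higher number from compound 1 to compound 3 (0.38 log units; beyond the scatter). Compound 3 is therefore estimated at 200 nM, with a likely range from 60 nM to 700 nM.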

Compound 3, inhibition constant: 235 nM
Beside the measured number, compound 3's estimate is 1.2-fold (0.07 log units) below it; the range from low to high includes it.
By their numbers in this assay, from the lowest: compound 1; then compounds 3 and 2 (each within the scatter of the next).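

Among these compounds, replacing 3-carbamoylphenyl with 1H-imidazol-2-yl on a saturated chain carbon bound to a sulfur gives the first direct reading at this position (a 2.8-fold higher number from compound 1 to compound 3 (0.45 log units; beyond the scatter)). The step is modest, so inhibition survives an exchange of a six-membered carbon ring carrying a carbonyl group for a five-membered ring with 2 hetero atoms. No measurement here explains the size of this step. Still open, going by these compounds, is whether the difference follows the ring or the carbamoyl group. A plain benzyl group at this place would help separate the two.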